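The source may report more compounds than this note shows. Statements on the series, on what has been measured and on what is new or still open speak of the compounds shown alone.

Compound 2 `O=C(/C=C/c1cc2ccccc2[nH]c1=O)c1ccc(O)cc1` gives 22300 nM in a functional assay on HCC 2998 cells (Homo sapiens) for cytotoxicity, read by sulforhodamine B assay, with a stated time of 24 h (a higher number here means a weaker inhibitor of growth, a lower number a stronger inhibitor of growth), the highest of the two numbers at hand; compound 1 `COc1ccc(C(=O)/C=C/c2cc3ccccc3[nH]c2=O)cc1` gives 6490 nM. For the measured compounds named here, the only measured step, a 3.4-fold higher number from compound 1 to compound 2 (0.54 log units; beyond the scatter), follows hydrogen in place of methyl on an oxygen on an aromatic ring. Going by the values given here, compound 3 `O=C(/C=C/c1cc2ccccc2[nH]c1=O)c1ccc(Cl)cc1` differs from compound 2 by chloro in place of hydroxy on an aromatic carbon, a change that no measured step covers directly. Among the compounds with values here, since the one step shows that losing the methyl raised the number, the exchange of hydroxy for chloro is expected to bring compound 3 back toward the lower number of compound 1, a step of a 2.8-fold lower number from compound 2 to compound 3 (0.45 log units; beyond the scatter). Compound 3 is therefore estimated at 8000 nM, within 3000 nM to 25000 nM.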

Compound 3, concentration for total growth inhibition: 22300 nM
Compound 3: middle estimate off by 2.8-fold (0.45 log units), on the low side; measured number inside the range.
By their numbers in this assay, from the lowest: compound 1; then compounds 2 and 3 (each within the scatter of the next).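

In this assay the change from 4-hydroxyphenyl to 4-chlorophenyl gives no change at the digits printed from compound 2 to compound 3 (within the scatter) at this position, so a group with one hydrogen-bond donor and one acceptor and a group with neither cannot be told apart here. With a 3.4-fold higher number from compound 1 to compound 3 (0.54 log units; beyond the scatter) as the other new step, chloro sits no nearer to methoxy than hydroxy does, and methoxy alone stands apart among the three groups. Nothing measured here speaks to what lies behind this. As far as these compounds go, it remains open whether an amine or a carboxylic acid at this position would stay with chloro and hydroxy or move toward methoxy. From the compounds shown here alone, a longer chain on the oxygen in place of methyl is equally open.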